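A Methoxy Removal Tested Twice in a Cytotoxicity Series

The source may report more compounds than this note shows. Statements on the series, on what has been measured and on what is new or still open speak of the compounds shown alone.

The study concerns four related compounds examined in a functional assay on PC-3 cells (Homo sapiens) for cytotoxicity, read by WST assay, with a stated time of 24 h; on this read-out higher numbers stand for weaker inhibition and lower numbers for stronger inhibition. Compound 1 `N#C/C(=C\c1c[nH]c2cc(F)ccc12)C(=O)c1c[nH]c2ccccc12` returns only the limit of the assay, > 50000 nM. Compound 2 `COc1ccc2c(C(=O)/C(C#N)=C/c3c[nH]c4cc(F)ccc34)c[nH]c2c1` gives 36000 nM in this assay. Compound 3 `COc1ccc2c(C(=O)/C(C#N)=C/c3cn(Cc4ccc(Cl)cc4)c4ccccc34)c[nH]c2c1` also returns only a limit, > 50000 nM. Compound 4 `N#C/C(=C\c1cn(Cc2ccc(Cl)cc2)c2ccccc12)C(=O)c1c[nH]c2ccccc12` has not yet been measured in this assay.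

Compound 2 and compound 1 differ in one place, (hydrogen in place of methoxy on an aromatic carbon). That change produced an at least 1.3-fold higher number from compound 2 to compound 1 (0.14 log units; that floor lies within the scatter). The same change, (hydrogen in place of methoxy on an aromatic carbon), separates compound 3 from compound 4, and the surroundings of the site are described in the same words in both pairs, so it is the same change made a second time. The difference between the core of compound 2 and the core of compound 3 is not broken down here. Two of the three values sit at the limit, (the limit of > 50000 nM in this assay, at which 2 of the 3 values shown sit), which leaves little for a number to rest on.

For compound 4 the expected step is a step that the limit leaves unreadable from compound 3 to compound 4. This expectation rests on compound 3 already standing at the limit > 50000 nM. It rests as well on the earlier step of an at least 1.3-fold higher number from compound 2 to compound 1 (0.14 log units; that floor lies within the scatter), which went from a number to a limit. In this assay compound 4 is estimated at 80000 nM, with a likely range from 40000 nM to 200000 nM, and a limit rather than a number is the most likely outcome.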

Compound 4, half-maximal inhibitory concentration: > 50000 nM
Compound 4: only a limit was reported; the forecaster's own chance of this, stated with the estimate: 85%; the middle value does not contradict the limit.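

In this assay compound 4 returns only a limit, > 50000 nM. Compound 3 also stands at a limit, so no step can be read between compound 3 and compound 4, because neither has a number: the limit of > 50000 nM in this assay, at which 3 of the 4 values shown sit.

The compounds shown leave open whether hydrogen in place of methoxy changes the cytotoxicity of compound 3 at all, and by how much.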